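The compounds below may be only part of what the source reports. "The series", "measured", "known", "first", "only" and "open" are said of these compounds alone.

Working notes on the series. Compound 1 `COc1ccc(C2CC(=O)C(Br)=CO2)cc1` in a functional assay on NCI-H460 cells (Homo sapiens) for inhibition, read by sulforhodamine B assay, with a stated time of 48 h (a higher number here means a weaker inhibitor of growth, a lower number a stronger inhibitor of growth), gives 118 uM. Compound 2 `COc1ccc(/C=C/C2CC=CC(=O)N2)cc1` in this assay gives only a limit, > 1090 uM. Compound 3 `COc1ccc(/C=C/C2CC=CC(=O)N2)c(OC)c1` in this assay likewise gives only a limit, > 964 uM. Among the compounds with values here, compound 3 therefore stands at a limit with no number of its own; the single step measured, a step that the two limits leave unreadable from compound 2 to compound 3, runs between two such limits and cannot be read, as the limit of > 1090 uM in this assay, at which 1 of the 3 values shown sits, and the limit of > 964 uM in this assay, at which 1 of the 3 values shown sits, show. Compound 4 `COc1cc(OC)c(OC)cc1/C=C/C1CC=CC(=O)N1` differs from compound 3 by methoxy in place of hydrogen on an aromatic carbon. Within the data shown here, the only step that bears on this change is that unreadable one, so no direction can be taken from it. The expected step that the limit leaves unreadable from compound 3 to compound 4 is small. Compound 4 is expected to come out again at a limit in this assay, estimated at 1000 uM with a range from 300 uM to 3000 uM.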

Compound 4, concentration for growth inhibition (reported as GI): > 864 uM
Compound 4 gave a limit, no number (the forecaster's own chance of this, stated with the estimate: 85%); the middle value lies beyond the limit too.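

Compound 3 and compound 4 both stand only at limits in this assay, so the step between them cannot be read. The compounds shown leave open whether methoxy in place of hydrogen on an aromatic carbon changes growth inhibition at all.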